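Working notes: from compound 3 to compound 4

This account rests on a few compounds, and the source may have more. Where it says the series, first, only, none or still open, it means among the compounds named here.

Values in a functional assay on MCF7 cells (Homo sapiens) for cytotoxicity, read by sulforhodamine B assay; on this read-out higher numbers stand for weaker inhibition of growth and lower numbers for stronger inhibition of growth:
- compound 1 `CC1=CC[C@@H]([C@@](C)(O)CCCC(C)(C)NC=S)CC1` gives 63100 nM
- compound 2 `COc1ccc(/C=N\NC(=S)NC(C)(C)CCC[C@](C)(O)[C@@H]2CC=C(C)CC2)cc1` gives 94900 nM
- compound 3 `CC1=CC[C@@H]([C@@](C)(O)CCCC(C)(C)NC(=S)N/N=C\c2ccc(N(C)C)cc2)CC1` gives > 100000 nM (a limit of the assay, not a number)

Compound 3 has no number of its own and sits at the limit of > 100000 nM in this assay, at which 1 of the 3 values shown sits.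

Compound 4 `CC1=CC[C@@H]([C@@](C)(O)CCCC(C)(C)NC(=S)N/N=C\c2ccccc2Cl)CC1` is the next one to read. It carries 2-chlorophenyl in place of 4-(dimethylamino)phenyl on a carbon with a double bond to nitrogen.

Among the measured compounds shown here, only one measured step bears on this change, and only indirectly. It is an at least 1.0-fold higher number from compound 2 to compound 3 (0.02 log units; that floor lies within the scatter), with dimethylamino in place of methoxy on an aromatic carbon. For the measured compounds named here, no measured step brings in 2-chlorophenyl. The values of compound 1 and compound 2 lie within the scatter of each other.

On this evidence, no step beyond the scatter is expected in this assay, and no direction can be firmly assigned. The expectation rests on the nearest numbers in the series, compound 2 at 94900 nM and compound 1 at 63100 nM. The estimate amounts to an expected at least 1.1-fold lower number from compound 3 to compound 4 (0.07 log units; that floor lies within the scatter). For compound 4 the estimated value is 85000 nM, with an expected range from 45000 nM to 150000 nM.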

Compound 4, concentration for total growth inhibition: > 100000 nM
Compound 4 was reported as a limit; the forecaster's own chance of this, stated with the estimate: 40%; at least 1.1-fold (0.07 log units) between middle value and limit.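

In this assay compound 4 gives > 100000 nM, a limit of the assay and not a number, and the step that links it to compound 3 cannot be read, since that compound also carries a limit. Among the compounds shown here, the one readable step is an at least 1.0-fold higher number from compound 2 to compound 4 (0.02 log units; that floor lies within the scatter), with 2-chlorophenyl in place of 4-methoxyphenyl on a carbon with a double bond to nitrogen, so this change gives no sign of stronger inhibition of growth than compound 2 shows. New here is that a chlorine-bearing aryl group at this place, with 2-chlorophenyl in place of 4-(dimethylamino)phenyl, ends at the same limit as compound 3: the limit of > 100000 nM in this assay, at which 2 of the 4 values shown sit.

From the compounds shown here alone, how far compound 3 and compound 4 lie past that limit stays open, and so does any ranking among the aryl groups at this place. Also open, going by these compounds, is whether a pyridine ring, a carboxylic acid or a simple amine on the carbon with a double bond to nitrogen would give a readable number in this assay.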